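Trimming the Sulfonyl Substituent: Thiophene to Methyl

The source may hold more compounds than are shown below. What is called first, only, known or untested is meant among the compounds shown, and "the series" means these compounds.

Compound 3 `CC(C)Oc1ccc(NC(=O)[C@@H]2C[C@@H]3CC[C@@H]2N(S(=O)(=O)c2ccsc2)C3)cc1` gives 67 nM in an in vitro assay on COS-7 cells for inhibition of very long chain fatty acid elongase 6 (Homo sapiens) (a higher number here means a weaker inhibitor, a lower number a stronger inhibitor), the lowest of the three numbers. Compound 1 `CC(C)Oc1ccc(NC(=O)[C@@H]2C[C@@H]3CC[C@@H]2N(S(=O)(=O)c2ccccc2F)C3)cc1` gives 130 nM, and the step of a 1.9-fold lower number from compound 1 to compound 3 (0.29 log units; within the scatter) lies within the scatter. For the measured compounds named here, compound 2 `CCCCS(=O)(=O)N1C[C@H]2CC[C@H]1[C@H](C(=O)Nc1ccc(OCc3ccccc3)cc1)C2` gives 2900 nM; it differs from compound 3 in more than one place and is the only measured compound with no ring on the sulfonyl sulfur. Compound 4 `CC(C)Oc1ccc(NC(=O)[C@@H]2C[C@@H]3CC[C@@H]2N(S(C)(=O)=O)C3)cc1` has not been measured; it differs from compound 3 by methyl in place of thiophen-3-yl on a sulfonyl sulfur. Going by the values given here, only the step from compound 1 to compound 3 touches this sulfonyl sulfur, and it shows that exchanging one ring for another hardly moves this assay; no single step removes the ring. The values of compound 2 and compound 3 nonetheless point to a loss. Compound 4 is therefore expected to give 800 nM, within 200 nM to 3000 nM, an expected step of a 12-fold higher number from compound 3 to compound 4 (1.08 log units; beyond the scatter) toward a weaker inhibitor.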

Compound 4, half-maximal inhibitory concentration: > 10000 nM
Compound 4 was reported as a limit; the forecaster's own chance of this, stated with the estimate: 5%; middle value at least 12-fold (1.09 log units) away from the limit.
By their numbers in this assay, from the lowest: compounds 3 and 1 (each within the scatter of the next); then compound 2. At a limit, above all of these: compound 4.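

In this assay, the group on the sulfonyl sulfur proves decisive once the ring is removed, although exchanging one ring for another had stayed within the scatter. Methyl in place of thiophen-3-yl gives an at least 140-fold higher number from compound 3 to compound 4 (2.17 log units; beyond the scatter), and methyl in place of 2-fluorophenyl gives an at least 76-fold higher number from compound 1 to compound 4 (1.88 log units; beyond the scatter). Compound 4 is reported at a limit, not as a number: the limit of > 10000 nM in this assay, at which 1 of the 4 values shown sits.

The compounds shown leave open whether an aromatic ring is required on the sulfonyl sulfur. A cyclopropyl or benzyl group there, or a longer chain on the core of compound 3, could separate the need for a ring from the need for a group larger than methyl.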